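The compounds below may be only part of what the source reports. "The series", "measured", "known", "first", "only" and "open" are said of these compounds alone.

Measured compounds:
compound 1, `CCOc1nc(Cl)cc(NC(=O)NCc2cc(C)c(-c3cn(C)nc3C(F)(F)F)nn2)c1C`, 15 nM
compound 2, `CCOc1nc(C#N)cc(NC(=O)NCc2cc(C)c(-c3cn(C)nc3C(F)(F)F)nn2)c1C`, 24 nM
compound 3, `CCOc1nc(C)cc(NC(=O)NCc2cc(C)c(-c3cn(C)nc3C(F)(F)F)nn2)c1Cl`, 26 nM

Three urea-linked compounds have been tested in a functional assay on CHO cells for antagonist activity at sphingosine 1-phosphate receptor 2 (Homo sapiens), read by scintillation counting and GTPgammaS binding, with a stated time of 4 h, in the presence of a further agent that is not named here; a higher number here means a weaker inhibitor, a lower number a stronger inhibitor; compound 4, `CCOc1nc(C)cc(NC(=O)NCc2cc(C)c(-c3cn(C)nc3C(F)(F)F)nn2)c1C#N`, has not. Compound 1 and compound 2 differ by cyano in place of chloro on an aromatic carbon, a change that gave a 1.6-fold higher number from compound 1 to compound 2 (0.20 log units; within the scatter). Compound 1 and compound 3 are built from the same atoms joined differently: 3-chloro-2-ethoxy-6-methylpyridin-4-yl in place of 6-chloro-2-ethoxy-3-methylpyridin-4-yl on an amide-type nitrogen, which gave a 1.7-fold higher number from compound 1 to compound 3 (0.24 log units; within the scatter). Among the measured compounds shown here, no step is computed between compound 2 and compound 3; in this assay compound 2 gives 24 nM and compound 3 gives 26 nM, values within the scatter of each other.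

Compound 4 arises from compound 3 by cyano in place of chloro on an aromatic carbon. This is the same kind of change as that from compound 1 to compound 2, but not the same: in compound 4 the new group sits ortho to a large group, ortho to an ethoxy group and two atoms from the ring nitrogen, whereas in compound 2 it sits next to the ring nitrogen, meta to a large group and meta to an ethoxy group; in both it is para to a methyl group.

The expectation rests on one measured step. Because the step of a 1.6-fold higher number from compound 1 to compound 2 (0.20 log units; within the scatter) stayed within the scatter, the step from compound 3 to compound 4 is expected to be similar, a 1.5-fold higher number from compound 3 to compound 4 (0.19 log units; within the scatter), though the different surroundings leave room for a larger move. Compound 4 is estimated at 40 nM, with a likely range of 18 nM to 90 nM.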

Compound 4, half-maximal inhibitory concentration: > 20000 nM
Compound 4: only a limit was reported; the forecaster's own chance of this, stated with the estimate: 3%; middle value at least 500-fold (2.69 log units) from the limit.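

Compound 4 gives > 20000 nM in this assay, and this is a limit of the assay and not a number. On these data alone, on the core of compound 3, cyano in place of chloro on an aromatic carbon gave an at least 760-fold higher number from compound 3 to compound 4 (2.88 log units; beyond the scatter), so the small step seen on the core of compound 1 did not carry over: the same change on two cores in this assay, a 1.6-fold higher number (0.20 log units; within the scatter) from compound 1 to compound 2 and an at least 760-fold higher number (2.88 log units; beyond the scatter) from compound 3 to compound 4, at least 480-fold (2.68 log units) apart, beyond the scatter of two such steps This shows that the outcome of the change on one core could not be read across to the other, but it does not show what separates the two cores, and the full size of the step stays unknown.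

The compounds shown leave open whether the result belongs to the cyano group itself or to its place, ortho to a large group and ortho to an ethoxy group, on the core of compound 3. A fluoro, methoxy or carboxamide group at that same place, or a longer chain in place of the ethoxy group beside the cyano, could help to tell these apart.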